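The source may hold more compounds than are shown below. What is called first, only, known or untested is meant among the compounds shown, and "the series" means these compounds.

Measured so far in an ADME assay on the whole organism (strain 129/SvEvBrd x C57BL/6) for metabolic stability, with Mus musculus as the target; on this read-out higher numbers stand for a longer-lived compound and lower numbers for a shorter-lived compound

- compound 1 `CC(=O)c1ncc([C@@H](O)[C@H](O)[C@H](O)CO)s1` gives 0.9 h
- compound 2 `CC(=O)c1nc([C@@H](O)[C@H](O)[C@H](O)CO)c(-c2ccccc2)[nH]1` gives 1.9 h
- compound 3 `CN(C)C(=O)c1nc([C@@H](O)[C@H](O)[C@H](O)CO)c[nH]1` gives 4 h

Compound 3 has the longest half-life of these three, and its gaps to compound 2 and to compound 1 both lie beyond the scatter. The next compound to be read is compound 4 `OC[C@@H](O)[C@@H](O)[C@H](O)c1c[nH]c(-c2cnccn2)n1`, which carries pyrazin-2-yl in place of dimethylcarbamoyl on an aromatic carbon, between two ring nitrogen atoms (pyrazin-2-yl in place of dimethylcarbamoyl on an aromatic carbon).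

Within the data shown here, no two measured compounds differ in one place only, so the series offers no direct measure of what this exchange does. The measured compounds also do not show how pyrazin-2-yl behaves at this position. Among the measured compounds shown here, the only guide is the overall range, in which compound 3 at 4 h sits at the top and compound 1 at 0.9 h sits at the bottom. A compound taken from the top of so small a range is more likely to fall than to rise on a change of this kind. In this assay the estimated 1.8-fold lower number from compound 3 to compound 4 (0.26 log units; within the scatter) is therefore a modest decrease, possibly not far beyond the scatter. Compound 4 is expected at 2.2 h, within an estimated range of 0.8 h to 5.5 h for now.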

Compound 4, half-life: 1.9 h
For compound 4 the middle estimate is 1.2-fold (0.06 log units) above the measured one, within the range that was stated.
By their numbers in this assay, from the lowest: compound 1; then compounds 2 and 4 (each within the scatter of the next); then compound 3.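

In this assay, among these compounds, pyrazin-2-yl in place of dimethylcarbamoyl on the aromatic carbon between two ring nitrogen atoms gives a 2.1-fold lower number from compound 3 to compound 4 (0.32 log units; beyond the scatter) and is the first single change that can be read. The half-life therefore responds to the group at this position, although the step is only modest, and a group with no ring can give way to one six-membered aromatic ring with 2 hetero atoms at that modest cost. No measurement on hand accounts for the step, so this single pair records its size and direction but gives no reason for it.

From the compounds shown here alone, it remains open whether this step belongs to pyrazin-2-yl in particular or would also appear with another aromatic ring at this position, such as phenyl or pyridin-2-yl, and what a non-aromatic group such as a primary amide, a carboxylic acid or an amine would give there. Going by these compounds, it is also open whether the same exchange would give a step of similar size with a phenyl group on the neighbouring part of the core, as in compound 2.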